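Amide nitrogen substituent in a stilbene-ether pyridine series

The source may report more compounds than this note shows. Statements on the series, on what has been measured and on what is new or still open speak of the compounds shown alone.

Compound 3 `CNC(=O)c1cc(Oc2ccc(/C=C/c3ccncc3)cc2)ccn1` is measured in a functional assay on A549 cells (Homo sapiens) for antiproliferative activity, read by CCK-8 assay, with a stated time of 48 h (on this read-out lower numbers stand for stronger inhibition and higher numbers for weaker inhibition), at 13200 nM. Compound 1 `CNC(=O)c1cc(Oc2ccc(/C=C/c3ccccn3)cc2)ccn1` gives 17400 nM and compound 2 `CC(C)NC(=O)c1cc(Oc2ccc(/C=C/c3ccccn3)cc2)ccn1` gives 21400 nM, so all three numbers sit within the usual scatter of one another and no order among them can be read. The change from compound 3 to compound 4 `O=C(NCc1ccc(F)cc1)c1cc(Oc2ccc(/C=C/c3ccncc3)cc2)ccn1` is 4-fluorophenyl in place of hydrogen on a saturated chain carbon bound to an amide-type nitrogen. Going by the values given here, the one measured step that touches the amide-type nitrogen is a 1.2-fold higher number from compound 1 to compound 2 (0.09 log units; within the scatter), which shows that a larger group on that nitrogen left the number essentially unchanged. The other measured step, a 1.3-fold lower number from compound 1 to compound 3 (0.12 log units; within the scatter), concerns the pyridyl end and was likewise within the scatter. A 4-fluorophenyl on the saturated chain carbon is a larger addition than either measured step covers, so the data give no firm direction; the expected step in this assay is a 1.5-fold lower number from compound 3 to compound 4 (0.17 log units; within the scatter), not clearly beyond the scatter. Compound 4 is therefore estimated at 9000 nM, with a range from 2500 nM to 30000 nM.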

Compound 4, half-maximal inhibitory concentration: 18200 nM
For compound 4 the middle estimate is 2.0-fold (0.31 log units) below the measured one, within the range that was stated.
By their numbers in this assay, from the lowest: compounds 3, 1, 4 and 2 (each within the scatter of the next).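

The change from methyl to 4-fluorobenzyl on the amide-type nitrogen gives, in this assay, a 1.4-fold higher number from compound 3 to compound 4 (0.14 log units; within the scatter) and so leaves the number not distinguishable from that of compound 3. The earlier step at this nitrogen reached only isopropyl and was read with pyridin-2-yl at the other end of the molecule. This result extends the same reading to a group carrying a six-membered aromatic ring of carbon, here with pyridin-4-yl at that end. No measurement at hand bears on why this position tolerates the change.

Still open, as far as these compounds go, is whether a carboxylic acid, a morpholine or a longer chain ending in an amine on this nitrogen would move the number beyond the scatter. Also open, from the compounds shown here alone, is whether 4-fluorobenzyl would read the same with pyridin-2-yl in place of pyridin-4-yl.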